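Swapping a Short Chain for a Methoxybenzyl Arm

The compounds below may be only part of what the source reports. "The series", "measured", "known", "first", "only" and "open" are said of these compounds alone.

Compound 1 `CN(Cc1ccccc1)C(=O)c1ccc(-c2cc(C3=CC(=O)C=CC3=O)no2)s1` and compound 2 `CCCN(C)C(=O)c1ccc(-c2cc(C3=CC(=O)C=CC3=O)no2)s1` share one core and differ only in the group carried on the carbon bound to the amide-type nitrogen. In a functional assay on PC-3 cells (Homo sapiens) for cytotoxicity, read by XTT assay, with a stated time of 72 h (on this read-out lower numbers stand for stronger inhibition and higher numbers for weaker inhibition), compound 1 gives 11000 nM. For compound 2 the result in this assay is only a limit, < 30000 nM. The step that the limit leaves unreadable from compound 1 to compound 2 cannot be sized because of the limit of < 30000 nM in this assay, at which 1 of the 2 values shown sits. Compound 3 `COc1ccc(CN(C)C(=O)c2ccc(-c3cc(C4=CC(=O)C=CC4=O)no3)s2)cc1` arises from compound 2 by 4-methoxyphenyl in place of ethyl on a saturated chain carbon bound to an amide-type nitrogen. For the measured compounds named here, no measured step covers this change; compound 1, which carries a benzyl group, is the closest guide. The expected shift is a step that the limit leaves unreadable from compound 2 to compound 3. Compound 3 is estimated at 10000 nM, within 4000 nM to 30000 nM.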

Compound 3, half-maximal inhibitory concentration: < 30000 nM
Compound 3: only a limit was reported (the forecaster's own chance of this, stated with the estimate: 25%); the middle value lies beyond the limit too.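

No step to compound 3 can be sized, from either compound 1 or compound 2, because the result for compound 3 is only a limit: the limit of < 30000 nM in this assay, at which 2 of the 3 values shown sit.

Going by these compounds, how far propyl, benzyl and 4-methoxybenzyl truly differ in strength stays open.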